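The source may report more compounds than this note shows. Statements on the series, on what has been measured and on what is new or still open speak of the compounds shown alone.

Measured in an ADME assay on microsomes from liver (Rattus norvegicus) for metabolic stability, read by LC-MS, using NADPH, at 37 degrees C; on this read-out lower numbers stand for a shorter-lived compound and higher numbers for a longer-lived compound:

- Compound 1 `Cc1ccccc1-c1nc(CN2CCC(C(=O)NCCCN3CC(C)(C)CC(C)(C)C3)CC2)c(C)o1` gives 0.095 h
- Compound 2 `Cc1ccccc1-c1nc(CN2CCC(C(=O)NCCCN3CCC(C(C)C)CC3)CC2)c(C)o1` gives 0.147 h
- Compound 3 `Cc1ccccc1-c1nc(CN2CCC(C(=O)NCCCN3CCCCC3)CC2)c(C)o1` gives > 0.5 h

Compound 3 stands at > 0.5 h, which is a limit of the assay and not a number. The same limit is noted in the limit of > 0.5 h in this assay, at which 1 of the 3 values shown sits. Its true half-life in this assay is therefore unknown, and any comparison with it has one open end.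

Compound 4 `Cc1ccccc1-c1nc(CN2CCC(C(=O)N3CCN(CCN(C)C)CC3)CC2)c(C)o1` differs from compound 3 by 4-(2-(dimethylamino)ethyl)piperazin-1-yl in place of (3-(piperidin-1-yl)propyl)amino on a carbonyl carbon. The change sits on a carbonyl carbon. Within the data shown here, no measured step touches that place directly, so the evidence is indirect.

The step of a 1.5-fold higher number from compound 1 to compound 2 (0.19 log units; within the scatter) lies within the scatter. The steps of an at least 5.2-fold higher number from compound 1 to compound 3 (0.72 log units; beyond the scatter) and an at least 3.4-fold higher number from compound 2 to compound 3 (0.53 log units; beyond the scatter) lie beyond it, and both end at the limit of compound 3. Like compound 3, compound 4 has no isopropyl on a saturated ring carbon, the change behind an at least 3.4-fold higher number from compound 2 to compound 3 (0.53 log units; beyond the scatter). On that ground, no fall to the level of compound 1 or compound 2 is expected, and no step beyond the scatter is predicted in either direction.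

The expected change is a number no higher from compound 3 to compound 4 (the limit leaves the size open). For compound 4 the estimated half-life is 0.5 h, with an expected range from 0.2 h to 1 h.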

Compound 4, half-life: > 0.5 h
Compound 4: no number, only a limit; the forecaster's own chance of this, stated with the estimate: 50%; the middle value lies on the limit itself.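

In this assay compound 4 gives > 0.5 h, which is a limit of the assay and not a number. Compound 3 gives > 0.5 h, also a limit, so no step from compound 3 to compound 4 can be read: the limit of > 0.5 h in this assay, at which 2 of the 4 values shown sit.

The compounds shown leave open whether 4-(2-(dimethylamino)ethyl)piperazin-1-yl in place of (3-(piperidin-1-yl)propyl)amino changes the half-life at all.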